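The source may hold more compounds than are shown below. What is called first, only, known or untested is meant among the compounds shown, and "the series" means these compounds.

Of the compounds shown here, three have been measured in an assay for inhibition of C-X-C chemokine receptor type 1 (Homo sapiens), read by radioligand binding; on this read-out higher numbers stand for weaker inhibition and lower numbers for stronger inhibition. Compound 1 `O=C(Nc1ccccc1)Nc1cc([N+](=O)[O-])ccc1O` gives 46200 nM, and compound 3 `O=C(Nc1ccccc1)Nc1cccc([N+](=O)[O-])c1O` gives 33200 nM. Compound 2 `N#Cc1ccc(NC(=O)Nc2ccccc2Br)c(O)c1Cl` gives 4200 nM, the lowest of the three numbers, and its gap to either of the other two lies beyond the usual scatter, so on these numbers compound 2 is the strongest inhibitor.

The next compound to consider is compound 4 `N#Cc1ccc(NC(=O)Nc2ccccc2Br)c(O)c1`, which differs from compound 2 in one place: hydrogen in place of chloro on an aromatic carbon. The place is on an aromatic carbon of a six-membered aromatic ring of carbon only, ortho to a cyano group and ortho to a hydroxy group, and meta to a large group.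

For the measured compounds named here, no measured pair shows what this change does, so the expectation rests on compound 2 alone. For compound 4 the expected outcome in this assay is a modest step toward a higher number, a 1.9-fold higher number from compound 2 to compound 4 (0.28 log units; within the scatter), with the loss of the chloro group counted against it. Compound 4 is therefore estimated at 8000 nM, within a range from 2500 nM to 25000 nM.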

Compound 4, half-maximal inhibitory concentration: 15100 nM
Estimate against measurement, compound 4: 1.9-fold (0.28 log units) below, and the stated range covers the measured number.
By their numbers in this assay, from the lowest: compound 2; then compound 4; then compounds 3 and 1 (each within the scatter of the next).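

For the compounds shown here, this is the first pair of compounds that differ in one place, so the chloro group can now be judged on its own. In this assay replacing it with hydrogen gives a 3.6-fold higher number from compound 2 to compound 4 (0.56 log units; beyond the scatter) and so weaker inhibition, which means that in this pair the chloro group, on the carbon ortho to a cyano group and ortho to a hydroxy group, goes with the stronger inhibitor. Nothing at hand says why this swap changes inhibition.

On these data alone, what stays open is whether chlorine itself matters at this carbon, or whether fluorine, bromine, a methyl group or a methoxy group would serve as well. A single pair also cannot show whether the same swap would give a similar step on a compound with other groups elsewhere on the core.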